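Removing the Alkyne Substituent: Expectation for Compound 4

The compounds below may be only part of what the source reports. "The series", "measured", "known", "first", "only" and "open" are said of these compounds alone.

Of the compounds shown here, three sharing one core have been measured in an assay on isolated protein for binding affinity to vitamin D3 receptor (Homo sapiens), read by fluorescence polarization, tested at 1 uM; a lower number here means less inhibition, a higher number more inhibition at the concentration tested (going by the name of the read-out). Compound 1 `CCCC(O)(C#Cc1ccc(C(CC)(CC)C2=CN(CC)C(C(=O)NCCN(CC)CC)C2)cc1C)CCC` gives 51.1%, compound 2 `CCN(CC)CCNC(=O)C1CC(C(CC)(CC)c2ccc(C#CC(O)C3CCC3)c(C)c2)=CN1CC` gives 49.3%, and compound 3 `CCN(CC)CCNC(=O)C1CC(C(CC)(CC)c2ccc(C#CC(O)C3CCCCC3)c(C)c2)=CN1CC` gives 44.2%. Compound 3 stands lowest of the three, but its neighbours are close: the step of a number 5.1 percentage points lower from compound 2 to compound 3 (within the scatter) and the step of a number 6.9 percentage points lower from compound 1 to compound 3 (within the scatter) both stay within the scatter, as does a number 1.8 percentage points lower from compound 1 to compound 2 (within the scatter). Across these three the group on the triple-bonded carbon was exchanged while the hydroxyl-bearing carbon was kept each time, and the read-out hardly moved.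

Compound 4 `C#Cc1ccc(C(CC)(CC)C2=CN(CC)C(C(=O)NCCN(CC)CC)C2)cc1C` goes a step further: hydrogen in place of cyclohexyl(hydroxy)methyl on a triple-bonded carbon. Here the entire cyclohexyl(hydroxy)methyl group leaves, taking with it one hydrogen-bond donor and one hydrogen-bond acceptor, and only a hydrogen enters. For the measured compounds named here, no measured step mirrors this loss; the earlier steps only swapped one such group for another of comparable make-up. They therefore show that the shape of the group matters little, but say nothing about its absence. Because the steps of a number 1.8 percentage points lower from compound 1 to compound 2 (within the scatter) and a number 6.9 percentage points lower from compound 1 to compound 3 (within the scatter) and a number 5.1 percentage points lower from compound 2 to compound 3 (within the scatter) all stayed within the scatter, a modest remaining signal is plausible. Yet the loss of the whole group is expected to cost inhibition, so compound 4 is estimated at 25% (range 5% to 45%), a step of a number 19.2 percentage points lower from compound 3 to compound 4 (beyond the scatter).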

Compound 4, a percentage reported as inhibition, at one concentration (the size of the read-out at that concentration, not a potency): "not active" (no number reported)
For compound 4 the study gives words and no number; the estimate stays without a comparison.
By their numbers in this assay, from the lowest: compounds 3, 2 and 1 (each within the scatter of the next).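

For the compounds shown here, for compound 4 the study reports only the words "not active" in this assay, so no step from compound 3 or any other compound to compound 4 can be read. Nothing available bears on the reason for this result. The compounds shown leave open how large the change is when cyclohexyl(hydroxy)methyl gives way to hydrogen.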